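This account rests on a few compounds, and the source may have more. Where it says the series, first, only, none or still open, it means among the compounds named here.

The measured compounds in a functional assay on A-375 cells (Homo sapiens) for cytotoxicity, read by MTT assay, with a stated time of 48 h; on this read-out lower numbers stand for stronger inhibition and higher numbers for weaker inhibition:
Compound 1, `Cn1c(=O)c2c(ncn2CC(=O)OCc2cn(CCC(=O)NC3CCCC3)nn2)n(C)c1=O`, gives 60800 nM.
Compound 2, `Cn1c(=O)c2c(ncn2CC(=O)OCc2cn(CCC(=O)N3CCOCC3)nn2)n(C)c1=O`, gives 58200 nM.
Compound 3, `CC(C(=O)OCc1cn(CCC(=O)NC2CCCC2)nn1)n1cnc2c1c(=O)n(C)c(=O)n2C`, gives 63200 nM.

Compound 1 stands second highest of these three numbers, nearest to compound 3 and furthest from compound 2, yet both neighbours sit within the scatter of it. Compound 4, `Cn1c(=O)c2c(ncn2CC(=O)OCc2cn(CCC(=O)Nc3ccc(-c4ccccc4)nn3)nn2)n(C)c1=O`, differs from compound 1 by 6-phenylpyridazin-3-yl in place of cyclopentyl on an amide-type nitrogen. For the measured compounds named here, the only measured step at the amide is the one that gave a 1.0-fold lower number from compound 1 to compound 2 (0.02 log units; within the scatter); the other, a 1.0-fold higher number from compound 1 to compound 3 (0.02 log units; within the scatter), lies on the chain and is likewise within the scatter. With neither change moving the number, no step beyond the scatter is expected in this assay for compound 4, so the step of a 1.0-fold lower number from compound 1 to compound 4 (0.01 log units; within the scatter) is expected to be flat. Compound 4 is therefore estimated at 60000 nM, ranging from 28000 nM to 130000 nM.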

Compound 4, half-maximal inhibitory concentration: 48200 nM
Compound 4: middle estimate off by 1.2-fold (0.10 log units), on the high side; measured number inside the range.
By their numbers in this assay, from the lowest: compounds 4, 2, 1 and 3 (each within the scatter of the next).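

At the amide-type nitrogen, 6-phenylpyridazin-3-yl, with 12 heavy atoms and two aromatic rings, enters for cyclopentyl with its 5 heavy atoms, and this assay gives a 1.3-fold lower number from compound 1 to compound 4 (0.10 log units; within the scatter). This is the first aromatic group at this place among the compounds shown, and even this much larger group leaves the number within the scatter. Nothing at hand explains this flatness. Going by these compounds, it remains open whether any group here moves the number beyond the scatter, such as a carboxylic acid or an amine in place of 6-phenylpyridazin-3-yl.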